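A few compounds are considered here, and "the series" means these few. Any claim that something is new, unique, unknown or untested is made for them only; others in the source may bear on it.

Working notes on the series. The shared core carries a hydroxamic acid on one side chain and an aryl ketone on the other. Compound 1 `Cn1cc(/C=C/C(=O)c2ccccc2)cc1/C=C/C(=O)NO` is the member with an unsubstituted phenyl; in an assay on isolated protein for inhibition of histone deacetylase HD1B (Zea mays) (a higher number here means a weaker inhibitor, a lower number a stronger inhibitor), compound 1 gives 260 nM. Compound 2 `Cn1cc(/C=C/C(=O)c2ccccc2Cl)cc1/C=C/C(=O)NO` gives 1600 nM in this assay, and compound 3 `Cn1cc(/C=C/C(=O)c2ccccc2F)cc1/C=C/C(=O)NO` gives 3400 nM. Compound 3 thus stands highest of the three numbers, with compound 2 nearest and compound 1 furthest. The steps that lead to it are a 6.2-fold higher number from compound 1 to compound 2 (0.79 log units; beyond the scatter) and a 13-fold higher number from compound 1 to compound 3 (1.12 log units; beyond the scatter), while a 2.1-fold higher number from compound 2 to compound 3 (0.33 log units; beyond the scatter) separates the two halogenated members from each other.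

Compound 4 `Cn1cc(/C=C/C(=O)c2cccc(Br)c2)cc1/C=C/C(=O)NO` is not yet measured. It differs from compound 3 by 3-bromophenyl in place of 2-fluorophenyl on a carbonyl carbon. Among the measured compounds shown here, no measured step puts a halogen at the position of the phenyl that compound 4 uses, so the steps above bear on it only indirectly: both show that 2-halophenyl in place of phenyl raised the number. Whether 3-bromophenyl does the same cannot be read from them; compound 1 marks the number for the plain phenyl. The expectation is therefore a step back toward compound 1, a 4.9-fold lower number from compound 3 to compound 4 (0.69 log units; beyond the scatter), held with wide uncertainty. Compound 4 is estimated at 700 nM in this assay, within a range of 150 nM to 3500 nM.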

Compound 4, half-maximal inhibitory concentration: 480 nM
For compound 4 the middle estimate is 1.5-fold (0.16 log units) above the measured one; measured number inside the range.
By their numbers in this assay, from the lowest: compounds 1 and 4 (each within the scatter of the next); then compound 2; then compound 3.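

Among the aryl groups on the carbonyl carbon, 3-bromophenyl does not follow the two 2-halophenyl groups: 3-bromophenyl in place of 2-fluorophenyl gives a 7.1-fold lower number from compound 3 to compound 4 (0.85 log units; beyond the scatter) in this assay and in place of 2-chlorophenyl gives a 3.3-fold lower number from compound 2 to compound 4 (0.52 log units; beyond the scatter) in the same assay. Set against the plain phenyl, the bromo group gives a 1.8-fold higher number from compound 1 to compound 4 (0.27 log units; within the scatter) and so separates compound 4 from compound 2 and compound 3, which means a halogen on this phenyl does not in itself go with a raised number in this set of four compounds. Nothing at hand bears on why these aryl groups differ.

On these data alone, both steps from the 2-halophenyl members change the halogen and its place on the phenyl together, so the share of each stays open, and 2-bromophenyl and 3-fluorophenyl are the groups that would separate the two. Also open, as far as these compounds go, is whether the number stays close to that of compound 1 when the bromine of 3-bromophenyl gives way to a non-halogen such as an amine, a carboxylic acid or a methoxy group.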